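Compound 4: a methyl step near the assay limit

The source may hold more compounds than are shown below. What is called first, only, known or untested is meant among the compounds shown, and "the series" means these compounds.

Three members of the series have been read in a functional assay on A-375 cells (Homo sapiens) for antiproliferative activity, read by MTT assay, with a stated time of 72 h; on this read-out lower numbers stand for stronger inhibition and higher numbers for weaker inhibition. Compound 1 `COc1cccc(N2C(=O)COc3ccc(-c4cccc(NS(=O)(=O)c5ccc(F)cc5)c4)cc32)c1` gives > 40000 nM, which is a limit and not a number. Among the compounds with values here, compound 2 `O=C1COc2ccc(-c3cccc(NS(=O)(=O)c4ccc(F)cc4)c3)cc2N1c1ccc(Cl)cc1` gives 32500 nM, the one true number so far. Compound 3 `O=C1COc2ccc(-c3cccc(NS(=O)(=O)c4ccc(F)cc4)c3)cc2N1c1ccccc1` gives > 40000 nM, which is also a limit. The series therefore sits largely at the limit of > 40000 nM in this assay, at which 2 of the 3 values shown sit, and compound 3 offers only a limit as a starting point.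

Compound 4 `Cc1ccc(N2C(=O)COc3ccc(-c4cccc(NS(=O)(=O)c5ccc(F)cc5)c4)cc32)cc1` carries methyl in place of hydrogen on an aromatic carbon, which is methyl in place of hydrogen on an aromatic carbon, or phenyl to 4-methylphenyl.

The closest measured change is the loss of chloro from the 4-chlorophenyl of compound 2, which gives an at least 1.2-fold higher number from compound 2 to compound 3 (0.09 log units; that floor lies within the scatter). The exchange of aryl groups gives an at least 1.2-fold lower number from compound 1 to compound 2 (0.09 log units; that floor lies within the scatter), also a small floor. The remaining step, a step that the two limits leave unreadable from compound 1 to compound 3, adds no readable size.

None of these steps shows a size beyond the scatter, so no step beyond the scatter is expected in this assay, and a reading at the limit is the likelier outcome. The expected step is an at least 1.1-fold lower number from compound 3 to compound 4 (0.04 log units; that floor lies within the scatter). For compound 4 the estimated value is 36000 nM, with an expected range of 20000 nM to 50000 nM.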

Compound 4, half-maximal inhibitory concentration: 36200 nM
Compound 4: the middle estimate sits 1.0-fold (0.00 log units) below what was measured, and the stated range covers the measured number.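

With 4-methylphenyl on the amide-type nitrogen in a ring, the methyl on the aromatic carbon para to a large group gives an at least 1.1-fold lower number from compound 3 to compound 4 (0.04 log units; that floor lies within the scatter), and the exchange of 3-methoxyphenyl for 4-methylphenyl gives an at least 1.1-fold lower number from compound 1 to compound 4 (0.04 log units; that floor lies within the scatter); both are only floors resting on limits, and neither shows a change beyond the scatter. Methyl in place of chloro gives a 1.1-fold higher number from compound 2 to compound 4 (0.05 log units; within the scatter), the first step at this position between two true numbers rather than limits. In this assay, within the data shown here, the methyl and chloro groups therefore cannot be told apart at this position, which the earlier compounds, with only one true number among them, could not show.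

The size of any effect of the unsubstituted phenyl and the 3-methoxyphenyl remains unreadable, and the series stays tied to the assay ceiling: the limit of > 40000 nM in this assay, at which 2 of the 4 values shown sit.
Going by these compounds, whether a carboxylic acid, an amine or a longer chain such as propyl in the place of the methyl would give a step beyond the scatter stays open.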